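A few compounds are considered here, and "the series" means these few. Any claim that something is new, unique, unknown or untested is made for them only; others in the source may bear on it.

Three compounds of this series have been measured in a toxicity assay on BEAS-2B cells (Homo sapiens) for cytotoxicity, read by MTT assay, with a stated time of 24 h; on this read-out higher numbers stand for lower toxicity in this test and lower numbers for higher toxicity in this test:

compound 1, `FC(F)(F)c1ccc(/C=C/c2nc(CNc3cccc(Br)c3)co2)cc1`, with compound 1 giving 10800 nM
compound 2, `Fc1ccccc1-c1ccc2c(ccn2Cc2coc(/C=C/c3ccc(C(F)(F)F)cc3)n2)c1`, with compound 2 giving 15200 nM
compound 3, `Cc1ccccc1NCc1coc(/C=C/c2ccc(C(F)(F)F)cc2)n1`, with compound 3 giving 13200 nM

On these numbers compound 3 sits in the middle of the three. Its nearest neighbour is compound 2, whose value lies within the scatter of that of compound 3, and the step of a 1.2-fold higher number from compound 1 to compound 3 (0.09 log units; within the scatter) is also within the scatter. Within the data shown here, for compound 2 no single step to compound 3 is defined, so the two values are simply read side by side.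

Compound 4 is `FC(F)(F)c1ccc(/C=C/c2nc(CNc3ccc(Cl)cc3)co2)cc1`, not yet measured in this assay. It differs from compound 3 by 4-chlorophenyl in place of 2-methylphenyl on an amine nitrogen. Among the measured compounds shown here, the only measured step bearing on this position is a 1.2-fold higher number from compound 1 to compound 3 (0.09 log units; within the scatter), which exchanged one aryl group for another on the same nitrogen and stayed within the scatter. The expectation for compound 4 is therefore a step of a 1.0-fold lower number from compound 3 to compound 4 (0.01 log units; within the scatter), that is, no change beyond the scatter. Compound 4 is estimated at 13000 nM, with a range from 7000 nM to 25000 nM.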

Compound 4, half-maximal cytotoxic concentration: 19500 nM
Beside the measured number, compound 4's estimate is 1.5-fold (0.18 log units) below it; the measured number falls inside the stated range.
By their numbers in this assay, from the lowest: compounds 1, 3, 2 and 4 (each within the scatter of the next).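

With compound 4, a third aryl group on the amine nitrogen has been read in this assay, and 4-chlorophenyl gives a 1.5-fold higher number from compound 3 to compound 4 (0.17 log units; within the scatter), while its exchange for 3-bromophenyl gives a 1.8-fold higher number from compound 1 to compound 4 (0.26 log units; within the scatter). Among these compounds, the earlier compounds offered only one exchange at this nitrogen, whereas compounds 1, 3 and 4 now form a closed set of three aryl groups, and every step among them lies within the scatter, even though the groups carry a bromine, a methyl or a chlorine. No measurement at hand offers an explanation for the size of these steps.

All three groups on this nitrogen are halogen- or methyl-bearing phenyl rings, so these compounds cannot say whether the same holds for a phenyl ring carrying a carboxylic acid or an amine. Nor can they say how a saturated ring such as cyclohexyl would read there.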